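Working notes: from the 4-methoxyphenyl to the phenyl compound

The source may report more compounds than this note shows. Statements on the series, on what has been measured and on what is new or still open speak of the compounds shown alone.

- compound 1 `FC(F)(F)c1ccc(-c2ccc3c(NCCCNCc4ccco4)ccnc3c2)cc1` gives 237 10^-6 cm/s in an ADME assay for permeability, using PAMPA, with a stated time of 30 min, at pH 7.4; on this read-out higher numbers stand for higher permeability and lower numbers for lower permeability
- compound 2 `COc1ccc(-c2ccc3c(NCCCNCc4ccco4)ccnc3c2)cc1` gives 237 10^-6 cm/s in this assay

For the measured compounds named here, on the numbers so far, compound 2 sits level with compound 1, its only measured neighbour. The next member of the series is compound 3 `c1ccc(-c2ccc3c(NCCCNCc4ccco4)ccnc3c2)cc1`, still unmeasured. The structural change is hydrogen in place of methoxy on an aromatic carbon, in words hydrogen in place of methoxy on an aromatic carbon, para to a large group, or 4-methoxyphenyl to phenyl.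

Going by the values given here, one measured step bears on this change. It shows no change at the digits printed from compound 1 to compound 2 (within the scatter), with methoxy in place of trifluoromethyl on an aromatic carbon. Among the compounds with values here, that step exchanged one substituent for another, and no measurement yet covers the phenyl without a substituent, so the support is a single pair. On the evidence of no change at the digits printed from compound 1 to compound 2 (within the scatter), no direction and no step beyond the scatter is expected in this assay for the loss of methoxy. The expected outcome is a 1.0-fold lower number from compound 2 to compound 3 (0.01 log units; within the scatter), an estimate and not a result. Compound 3 is estimated at 230 10^-6 cm/s, with an expected range of 120 10^-6 cm/s to 420 10^-6 cm/s for this compound.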

Compound 3, apparent permeability: 237 10^-6 cm/s
The estimate for compound 3 lay 1.0-fold (0.01 log units) below the measured number; measured number inside the range.
By their numbers in this assay, from the lowest: compounds 1, 2 and 3 (each within the scatter of the next).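

Working notes, continued. In this assay, taking methoxy off the aromatic carbon, para to a large group, gives no change at the digits printed from compound 2 to compound 3 (within the scatter), and taking trifluoromethyl off the same carbon gives no change at the digits printed from compound 1 to compound 3 (within the scatter). The earlier pair compared only one substituent with another, whereas these steps add the comparison with hydrogen: in this small set, a substituent at this position is not needed to keep the read-out at the level of compound 1, and hydrogen, methoxy and trifluoromethyl cannot be put in any order. No accompanying measurement accounts for this agreement among the three compounds.

Whether this holds for a carboxylic acid or an amine on the same carbon stays open, since all three groups shown are uncharged and the read-out has not yet been seen with a group of either kind there. Also open, from the compounds shown here alone, is whether a longer chain in place of the one shared here, or a change to the shared core, would move the number, as compounds 1, 2 and 3 differ only at this one position.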